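Cytotoxicity notes: phenyl for benzyl on the shared core

The source may hold more compounds than are shown below. What is called first, only, known or untested is meant among the compounds shown, and "the series" means these compounds.

Measured in an ADME assay on HepG2 cells (Homo sapiens) for cytotoxicity, read by luminescence, CellTiter-Glo and ATP content, with a stated time of 72 h (a higher number here means that more compound is needed for the effect, a lower number that less compound is needed), so far:
compound 1 `COc1ccccc1Oc1ccc2c(NCCCNCc3ccco3)ccnc2c1` — 6500 nM
compound 2 `c1ccc(Oc2ccc3c(NCCCNCc4ccco4)ccnc3c2)cc1` — 15200 nM
compound 3 `COc1cccc(CNCCCNc2ccnc3cc(Cc4ccccc4)ccc23)c1O` — 5720 nM

Compound 3 stands at the lowest of the three numbers in this assay. Its nearest neighbour is compound 1, whose value is within the scatter of compound 3, so no order between the two can be read; compound 2 lies furthest away, beyond the scatter, at the higher number.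

Within the data shown here, the only step between two measured compounds is a 2.3-fold higher number from compound 1 to compound 2 (0.37 log units; beyond the scatter), a modest shift that follows the loss of a methoxy group on an aromatic carbon.

Compound 4 `COc1cccc(CNCCCNc2ccnc3cc(-c4ccccc4)ccc23)c1O` is not yet measured. It differs from compound 3 by phenyl in place of benzyl on an aromatic carbon. Among the measured compounds shown here, no measured pair in this set exchanges a benzyl for a phenyl, and the one step that exists concerns a different group at a different place, so it bears on this change only in showing that a small change on an aromatic carbon moved the number modestly. Nothing here points to a direction.

Compound 4 is therefore expected to sit near compound 3, with a 1.0-fold higher number from compound 3 to compound 4 (0.02 log units; within the scatter) staying within the scatter. The estimate for compound 4 in this assay is 6000 nM, in the range 2800 nM to 13000 nM.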

Compound 4, half-maximal effective concentration: 3210 nM
Compound 4: middle estimate off by 1.9-fold (0.27 log units), on the high side; the range from low to high includes it.
By their numbers in this assay, from the lowest: compounds 4, 3 and 1 (each within the scatter of the next, the first and the last beyond it); then compound 2.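

In this assay, the exchange of benzyl for phenyl on this aromatic carbon gives (a 1.8-fold lower number from compound 3 to compound 4 (0.25 log units; within the scatter)), so compound 3 and compound 4 cannot be told apart here. Among these compounds, this is the first direct reading at this position: both groups hold one six-membered aromatic ring of carbon only and no hydrogen-bond donors or acceptors, and for this pair, the exchange leaves the reading inside the usual scatter, unlike the methoxy step on the other side-chain pair (a 2.3-fold higher number from compound 1 to compound 2 (0.37 log units; beyond the scatter)). Nothing available gives a measured reason for this outcome or connects it to any property of either group.

Among the compounds shown here, open is whether a longer chain such as phenethyl, an amine such as morpholine, or a carboxylic acid on this same aromatic carbon would shift the number beyond the scatter, since benzyl and phenyl are the only groups compared here on an otherwise unchanged compound. Also open, as far as these compounds go, is whether the same exchange would read alike with the side chain of compound 1, as that compound differs from compound 3 in more than one place and allows no direct comparison.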